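The source may report more compounds than this note shows. Statements on the series, on what has been measured and on what is new or still open speak of the compounds shown alone.

In a functional assay, read by fluorescence and spectrophotometry, with a stated time of 1 h (a lower number here means that less compound is needed, a higher number that more compound is needed for the effect), compound 1 (`CCCCCS(=O)(=O)/C=C/c1ccc(O)c(O)c1`) gives 8100 nM, compound 2 (`O=S(=O)(/C=C/c1ccc(O)c(O)c1)CCCCCCCO`) gives 5900 nM and compound 3 (`O=S(=O)(/C=C/c1ccc(O)c(O)c1)CCC1CCCC1`) gives 6800 nM. Compound 3 thus lies within the scatter of both other compounds, and the three values show no order.

The next compound is compound 4 (`O=S(=O)(/C=C/c1ccc(O)c(O)c1)CC1CCCO1`), with oxolan-2-yl in place of cyclopentylmethyl on a saturated chain carbon bound to a sulfonyl sulfur.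

Three measured steps offer the nearest guide. Exchanging propyl for cyclopentyl gave a 1.2-fold lower number from compound 1 to compound 3 (0.08 log units; within the scatter). Exchanging 5-hydroxypentyl for cyclopentyl gave a 1.2-fold higher number from compound 2 to compound 3 (0.06 log units; within the scatter). Placing 2-hydroxyethyl on the chain gave a 1.4-fold lower number from compound 1 to compound 2 (0.14 log units; within the scatter). All three are small and within the scatter. Among the measured compounds shown here, none of them, however, involves oxolan-2-yl, and no measured compound carries a ring with a hetero atom, so the evidence for this change is indirect.

On these steps, no change beyond the scatter is expected in this assay, in either direction. The estimated 1.1-fold higher number from compound 3 to compound 4 (0.04 log units; within the scatter) stays within the scatter. For compound 4 the expected value is 7500 nM, with an estimated range of 3500 nM to 15000 nM.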

Compound 4, half-maximal effective concentration: 10500 nM
For compound 4 the middle estimate is 1.4-fold (0.15 log units) below the measured one; measured number inside the range.
By their numbers in this assay, from the lowest: compounds 2, 3, 1 and 4 (each within the scatter of the next).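

In this assay, among the compounds shown here, oxolan-2-yl is the first ring with a hetero atom on a saturated chain carbon bound to a sulfonyl sulfur; in place of cyclopentylmethyl it gives a 1.5-fold higher number from compound 3 to compound 4 (0.19 log units; within the scatter) and brings one hydrogen-bond acceptor where the carbon-only ring has none. The same group gives a 1.8-fold higher number from compound 2 to compound 4 (0.25 log units; within the scatter) in place of 6-hydroxyhexyl and a 1.3-fold higher number from compound 1 to compound 4 (0.11 log units; within the scatter) in place of butyl, so open chains, a chain ending in hydroxyl, a carbon-only ring and a ring with oxygen all remain within the scatter of one another at this position. No supporting measurement is available to explain these numbers, and the reading therefore stops at the values themselves.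

From the compounds shown here alone, it remains open whether any group at this place gives a step beyond the scatter, for instance an amine or a carboxylic acid at the end of the chain, or a phenyl ring. Also open, going by these compounds, is whether moving the ring oxygen, as in oxolan-3-yl, changes the number, and how changes to the shared core would read, as all compounds here carry that same core.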